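Replacing (methanesulfonamido)methyl with fluoro on the aromatic carbon

A few compounds are considered here, and "the series" means these few. Any claim that something is new, unique, unknown or untested is made for them only; others in the source may bear on it.

- compound 1 `Cn1nc2c(=O)n(CC3(O)CCN(Cc4ccc(-c5ccco5)cc4Cl)CC3)cnc2c1-c1ccc(C2(N)CC2)cc1`: 0.617 h
- compound 2 `Cn1nc2c(=O)n(CC3(O)CCN(Cc4ccc(-c5ccco5)cc4Cl)CC3)cnc2c1-c1ccc(CNS(C)(=O)=O)cc1`: 0.433 h

In an ADME assay on microsomes from liver (Rattus norvegicus) for metabolic stability (on this read-out higher numbers stand for a longer-lived compound and lower numbers for a shorter-lived compound), compound 2 stands level with compound 1 once the scatter is allowed for. Compound 3 `Cn1nc2c(=O)n(CC3(O)CCN(Cc4ccc(-c5ccco5)cc4Cl)CC3)cnc2c1-c1ccc(F)cc1` has fluoro in place of (methanesulfonamido)methyl on an aromatic carbon. Among the compounds with values here, one measured step bears on this place: a 1.4-fold lower number from compound 1 to compound 2 (0.15 log units; within the scatter). Within the data shown here, no measured compound carries fluoro there, so the expectation is loose. No step beyond the scatter is expected, and the estimated step is a 1.2-fold higher number from compound 2 to compound 3 (0.06 log units; within the scatter). The estimate for compound 3 is 0.5 h, with an expected range of 0.25 h to 1.1 h.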

Compound 3, half-life: 0.75 h
Estimate against measurement, compound 3: 1.5-fold (0.18 log units) below; measured number inside the range.
By their numbers in this assay, from the lowest: compounds 2, 1 and 3 (each within the scatter of the next).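

In this assay fluoro replaces (methanesulfonamido)methyl with a 1.7-fold higher number from compound 2 to compound 3 (0.24 log units; within the scatter) and replaces 1-aminocyclopropyl with a 1.2-fold higher number from compound 1 to compound 3 (0.08 log units; within the scatter) and both steps stay within the scatter. This aromatic carbon therefore carries three quite different groups with no readable separation, even though fluoro has 1 heavy atom and no hydrogen-bond donors or acceptors. Nothing at hand explains this level behaviour. Still open, as far as these compounds go, is whether a carboxylic acid or a longer chain at this place would give a step beyond the scatter. The compounds shown also leave open how changes elsewhere on the shared core would read.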